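Thiourea cytotoxicity: ester in place of chloro

The source may hold more compounds than are shown below. What is called first, only, known or untested is meant among the compounds shown, and "the series" means these compounds.

Two diaryl thioureas have been measured in an ADME assay on MT4 cells (Homo sapiens) for cytotoxicity; a lower number here means that less compound is tolerated, a higher number that more compound is tolerated. Compound 1 `FC(F)(F)c1cccc(NC(=S)Nc2cccc(Br)c2)c1` gives 9200 nM. Compound 2 `FC(F)(F)c1cccc(NC(=S)Nc2ccc(Cl)cc2)c1` gives 6800 nM; this is the lowest of the two numbers, but the step of a 1.4-fold lower number from compound 1 to compound 2 (0.13 log units; within the scatter) lies within the scatter, so the two compounds cannot be ordered. Compound 3 `CCOC(=O)c1ccc(NC(=S)Nc2cccc(C(F)(F)F)c2)cc1` has not yet been measured in this assay. It differs from compound 2 by ethoxycarbonyl in place of chloro on an aromatic carbon. Going by the values given here, the only measured step, the one from compound 1 to compound 2, swaps one halogen-bearing phenyl for another and does not bear on an ethoxycarbonyl group; it was within the scatter. There is therefore no shown step to build on. Compound 3 is expected to stay close to compound 2, with a step of a 1.3-fold higher number from compound 2 to compound 3 (0.12 log units; within the scatter) that is not expected to exceed the scatter with any confidence. The estimate for compound 3 in this assay is 9000 nM, within 3000 nM and 27000 nM.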

Compound 3, half-maximal cytotoxic concentration: 23000 nM
Estimate against measurement, compound 3: 2.6-fold (0.41 log units) below; the measured number falls inside the stated range.
By their numbers in this assay, from the lowest: compounds 2 and 1 (each within the scatter of the next); then compound 3.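

In this assay, ethoxycarbonyl in place of chloro on this aromatic carbon, para to a large group, gives the only step shown that lies beyond the scatter, a 3.4-fold higher number from compound 2 to compound 3 (0.53 log units; beyond the scatter), so that more compound is tolerated. Going by these compounds alone, the step from compound 1 to compound 2 could not be told from the scatter, so this is the first sign that a change on this carbon can move the number at all, though the step is modest and rests on a single pair. Nothing available bears on why the number rises with this change.

The compounds shown leave open whether this shift belongs to the ester as such or would also follow from another group here, such as a carboxylic acid or a primary amide. They also leave open whether a methyl ester or a longer chain on the ester would move the number further.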